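The source may report more compounds than this note shows. Statements on the series, on what has been measured and on what is new or still open speak of the compounds shown alone.

Within the data shown here, in an ADME assay on liver for metabolic stability, with Liver microsome (Rattus norvegicus) as the target, using microsomes and NADPH, with a stated time of 30 min, tested at 0.5 uM (on this read-out lower numbers stand for slow clearance and higher numbers for fast clearance), three compounds have numbers so far. Compound 1 `O=c1[nH]ccn1CCOc1nn(-c2ccccc2F)c2ccc(F)cc12` gives 783 mL/min/kg, the second highest of the three. Compound 2 `CC(C)(O)CC(=O)N1CC[C@H]2CN(c3cccc4c3cnn4-c3ccccc3F)C(=O)[C@H]21` gives 98.3 mL/min/kg, a lower number, and compound 3 `CC(C)(C)OC(=O)NCCOc1cccc2c1cnn2-c1ccccc1F` gives 8550 mL/min/kg, a higher one. Both gaps from compound 1 lie beyond the usual scatter. Compound 4 `O=C(COc1nn(-c2ccccc2F)c2ccc(F)cc12)N1CCOCC1` keeps the core of compound 1 but carries (morpholin-4-yl)carbonyl on a saturated chain carbon bound to an oxygen on an aromatic ring: a group of 8 heavy atoms (5 carbon, 1 nitrogen, 2 oxygen; one six-membered non-aromatic ring with 2 hetero atoms) in place of a group of 7 heavy atoms (4 carbon, 2 nitrogen, 1 oxygen; one five-membered aromatic ring with 2 hetero atoms), on a saturated chain carbon bound to an oxygen on an aromatic ring. Among the measured compounds shown here, no measured pair shows a comparable swap, so no size or direction is supported, and no step beyond the scatter is expected. The expected step is a 1.1-fold lower number from compound 1 to compound 4 (0.05 log units; within the scatter). For compound 4 the estimated clearance is 700 mL/min/kg, within an expected range of 220 mL/min/kg to 2300 mL/min/kg.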

Compound 4, clearance: 183 mL/min/kg
The estimate for compound 4 lay 3.8-fold (0.58 log units) above the measured number; measured number below the stated range.
By their numbers in this assay, from the lowest: compounds 2 and 4 (each within the scatter of the next); then compound 1; then compound 3.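

In this assay the group at this place proves to matter: (morpholin-4-yl)carbonyl in place of the five-membered aromatic ring group gives a 4.3-fold lower number from compound 1 to compound 4 (0.63 log units; beyond the scatter) on a saturated chain carbon bound to an oxygen on an aromatic ring. The swap changes the ring and removes a hydrogen-bond donor at once, so this single step cannot separate those changes. Nothing measured here gives a reason for the step.

Still open, on these data alone, is whether a simple dimethylamide or a carboxylic acid on the same chain carbon would give a similar number. Also open, as far as these compounds go, is whether the morpholine ring or the carbonyl counts more.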